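Ethoxy for Methoxy in a Dihydropyridine Enol Ether

This account rests on a few compounds, and the source may have more. Where it says the series, first, only, none or still open, it means among the compounds named here.

Compounds measured in a functional assay (aorta) with Oryctolagus cuniculus as the target; on this read-out lower numbers stand for stronger inhibition and higher numbers for weaker inhibition:
- compound 1 `CCO/C(O)=C1\C(C)=NC(C)=C(C(=O)OCCCN2C(=O)c3ccccc3S2(=O)=O)C1c1cccc([N+](=O)[O-])c1` gives 1.9 nM
- compound 2 `CCO/C(O)=C1\C(C)=NC(C)=C(C(=O)OCCCN2C(=O)c3ccccc3S2(=O)=O)C1c1cccc(Cl)c1Cl` gives 1.8 nM
- compound 3 `CO/C(O)=C1\C(C)=NC(C)=C(C(=O)OCCCN2C(=O)c3ccccc3S2(=O)=O)C1c1ccccc1Cl` gives 1.8 nM

Compound 3 stands level with compound 2 at the digits reported, and the two together carry the lowest numbers of the three; its distance to compound 1 is also within the scatter, so the three measured compounds cannot be told apart on this read-out.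

Compound 4 `CCO/C(O)=C1\C(C)=NC(C)=C(C(=O)OCCCN2C(=O)c3ccccc3S2(=O)=O)C1c1ccccc1Cl` is the next step from compound 3. The change is methyl in place of hydrogen on a saturated chain carbon bound to an oxygen on an unsaturated carbon; cut one bond further out, it reads methyl to ethyl, or methoxy to ethoxy. Within the data shown here, none of the measured steps touches this chain: the only single-point step, a 1.1-fold lower number from compound 1 to compound 2 (0.02 log units; within the scatter), concerns the aryl group on the saturated ring carbon and lies within the scatter. Compounds 1 and 2 both carry the ethoxy group and sit at the same level as compound 3, which carries the methoxy group, so nothing in these data points to a shift of any size. The step from compound 3 to compound 4 is therefore expected to be no change at the digits printed from compound 3 to compound 4 (within the scatter), that is, no change beyond the scatter.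

Compound 4 is estimated at 1.8 nM, with a range from 0.9 nM to 3.6 nM.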

Compound 4, half-maximal inhibitory concentration: 3.9 nM
For compound 4 the middle estimate is 2.2-fold (0.34 log units) below the measured one; the whole stated range lies below it.
By their numbers in this assay, from the lowest: compounds 2, 3 and 1 (each within the scatter of the next); then compound 4.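

In this assay the chain on the oxygen turns out not to be silent: the added methyl on the saturated chain carbon bound to an oxygen on an unsaturated carbon gives a modest step (a 2.2-fold higher number from compound 3 to compound 4 (0.34 log units; beyond the scatter)), the first in this set to lie beyond the scatter. The ethoxy group alone does not set the level, however, for compound 1 and compound 2 carry it as well, and compound 4 stands apart from both through the aryl group on the saturated ring carbon (a 2.2-fold higher number from compound 2 to compound 4 (0.34 log units; beyond the scatter) and a 2.1-fold higher number from compound 1 to compound 4 (0.31 log units; beyond the scatter)), so among the ethoxy compounds the aryl group now shows a difference that the earlier step within the scatter did not. Nothing available explains why these steps come out as they do.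

The compounds shown leave open whether going from methoxy to ethoxy would give a similar step with the 3-nitrophenyl or 2,3-dichlorophenyl group in place of 2-chlorophenyl. They also leave open how a longer chain such as propoxy, or an amine carried at the end of the ethoxy chain, would read at this position.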